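The source may report more compounds than this note shows. Statements on the series, on what has been measured and on what is new or still open speak of the compounds shown alone.

Compound 1 `COC(=O)C1=C(C)N=C(C)/C(=C(\O)OC)C1c1ccccc1Cl` gives 2.19 nM in a functional assay (muscle tissue) with Cavia porcellus as the target; on this read-out higher numbers stand for an effect only at larger amounts of compound and lower numbers for an effect already at smaller amounts. Compound 3 `COC(=O)C1=C(C)N=C(C)/C(=C(\O)OC)C1c1cccc(Br)c1`, at 1.29 nM, cannot be told apart from it on this read-out, while compound 2 `COC(=O)C1=C(C)N=C(C)/C(=C(\O)OC)C1c1ccc(I)cc1`, at 22900 nM, lies far up the scale. Compound 1 therefore stands with compound 3 at the low end of the three numbers.

Compound 4 `CCOc1ccccc1C1C(C(=O)OC)=C(C)N=C(C)/C1=C(\O)OC` keeps the core of compound 1 and alters one substituent: ethoxy in place of chloro on an aromatic carbon. This puts ethoxy in place of chloro on an aromatic carbon, ortho to a large group.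

Within the data shown here, no measured step makes this exchange, so the evidence is indirect. The 3-bromophenyl in place of 2-chlorophenyl gave a 1.7-fold lower number from compound 1 to compound 3 (0.23 log units; within the scatter), within the scatter. The 4-iodophenyl in place of 2-chlorophenyl gave a 10000-fold higher number from compound 1 to compound 2 (4.02 log units; beyond the scatter), a large step. Changes to this aromatic group can thus leave this assay unmoved or shift it enormously, and the two steps set wide bounds. Compound 4 differs from compound 1 only in the group on the same aromatic carbon, so a moderate rise is expected, with wide uncertainty and nothing near the step to compound 2. The estimated step is a 14-fold higher number from compound 1 to compound 4 (1.14 log units; beyond the scatter). For compound 4 the expected value is 30 nM, with an estimated range from 3 nM to 300 nM.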

Compound 4, half-maximal effective concentration: 110 nM
Compound 4: the middle estimate sits 3.7-fold (0.56 log units) below what was measured; measured number inside the range.
By their numbers in this assay, from the lowest: compounds 3 and 1 (each within the scatter of the next); then compound 4; then compound 2.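

On the same aromatic carbon, ortho to a large group, ethoxy in place of chloro gives a 50-fold higher number from compound 1 to compound 4 (1.70 log units; beyond the scatter) in this assay. The earlier steps shown here each moved the substituent to a different aromatic carbon and changed the halogen with it, so they could not separate the place from the group; this step keeps the place and changes only the group, and the number still moves well beyond the scatter. Having a substituent at this place is therefore not enough to hold the low number of compound 1, since the identity of the group matters here, and no information on any property of these compounds bears on why the number rises.

With a single exchange at this carbon, the compounds shown do not tell whether the rise grows with the length of the group or depends on the oxygen that ethoxy brings, and a propoxy chain, a hydroxyl or an amine on the same carbon would speak to that. Among these compounds, also open is how ethoxy would read on another aromatic carbon of the ring, where the two halogens of the earlier compounds gave such different numbers.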